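The source may report more compounds than this note shows. Statements on the series, on what has been measured and on what is new or still open speak of the compounds shown alone.

Three compounds of one shared core have so far been put through a functional assay on the whole organism with Mus musculus as the target, in the rotarod test; on this read-out lower numbers stand for an effect already at smaller amounts and higher numbers for an effect only at larger amounts of compound. Compound 1, `NC(C(=O)NCC(=O)Nc1ccc(Cl)cc1C(=O)c1ccccc1)c1ccccc1`, reached only the limit of the assay and gave no number: in this assay compound 1 shows > 100 mg/kg. Compound 3, `CN(C(=O)CNC(=O)c1ccccc1)c1ccc(Cl)cc1C(=O)c1ccccc1`, likewise stopped at the limit, with > 100 mg/kg in this assay. Compound 2, `CN1CCN(CC(=O)NCC(=O)N(C)c2ccc(Cl)cc2C(=O)c2ccccc2Cl)CC1`, is the starting point of the step followed here, and for it too only a limit is on record: in this assay compound 2 gives > 100 mg/kg. All that can be said of where compound 2 stands is that its value sits with the other two at the limit of > 100 mg/kg in this assay, at which 3 of the 3 values shown sit, so no order among the three can be drawn.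

Compound 4, `CCCCCCC(=O)NCC(=O)N(C)c1ccc(Cl)cc1C(=O)c1ccccc1Cl`, is the compound still to be measured. It differs from compound 2 in one place: pentyl in place of 4-methylpiperazin-1-yl on a saturated chain carbon bound to a carbonyl carbon. Within the data shown here, no step between two measured compounds is available to set a scale for such a change, so the expectation rests only on the limits seen so far. Given that compound 2 shows only a limit in this assay, compound 4 is expected to behave much the same, with a step from compound 2 estimated at a step that the limit leaves unreadable from compound 2 to compound 4, that is no change beyond the scatter. The estimate for compound 4 in this assay is therefore 150 mg/kg, within a range from 60 mg/kg to 400 mg/kg, most likely reported again only as a limit.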

Compound 4, dose for half-maximal effect: 70 mg/kg
Compound 4: the middle estimate sits 2.1-fold (0.33 log units) above what was measured; measured number inside the range.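

In this assay, among these compounds, compound 4 gives 70 mg/kg, the first true number for this shared core, which shows that a compound with a change at this place, on a saturated chain carbon bound to a carbonyl carbon, can register inside the range of the assay. Compound 2 has only a limit of the assay and not a number, and it shares that place with both of the other earlier compounds: the limit of > 100 mg/kg in this assay, at which 3 of the 4 values shown sit. Pentyl in place of 4-methylpiperazin-1-yl therefore gives an at least 1.4-fold lower number from compound 2 to compound 4 (0.15 log units; that floor lies within the scatter), so the result establishes a direction only as far as that floor allows, and the true size of the step remains unknown.

As far as these compounds go, whether a shorter chain such as propyl, a longer chain such as octyl, or an open-chain amine such as dimethylamino would give a lower or a higher number at this place remains open. From the compounds shown here alone, it also remains open whether the ring of 4-methylpiperazin-1-yl or its nitrogen atoms matter here, as a carbon ring such as cyclohexyl would begin to tell.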